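Compound 3 and an isopropylcarbonyl swap on nitrogen

The source may report more compounds than this note shows. Statements on the series, on what has been measured and on what is new or still open speak of the compounds shown alone.

- compound 1 `COc1cc(/C=C2\CN(C)C/C(=C\c3cc(OC)c(OC)c(OC)c3)C2=O)cc(OC)c1OC` gives 1500 nM
- compound 2 `CCCN1C/C(=C\c2ccc(OC)c(OC)c2)C(=O)/C(=C/c2ccc(OC)c(OC)c2)C1` gives 16000 nM
- compound 3 `CCN1C/C(=C\c2cc(OC)c(OC)c(OC)c2)C(=O)/C(=C/c2cc(OC)c(OC)c(OC)c2)C1` gives 8200 nM

These numbers come from a functional assay on NCI-H1650 cells (Homo sapiens) for cytotoxicity, read by MTT assay, with a stated time of 72 h (on this read-out higher numbers stand for weaker inhibition and lower numbers for stronger inhibition), and they place compound 3 close to compound 2, since the two values lie within the usual scatter of each other. Compound 1 stands clearly apart from compound 3.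

Compound 4 `COc1cc(/C=C2\CN(C(=O)C(C)C)C/C(=C\c3cc(OC)c(OC)c(OC)c3)C2=O)cc(OC)c1OC` keeps the core of compound 3 and changes one group isopropylcarbonyl in place of ethyl on an amine nitrogen in a ring with isopropylcarbonyl in place of ethyl on an amine nitrogen in a ring.

Within the data shown here, one measured step bears on this: a 5.5-fold higher number from compound 1 to compound 3 (0.74 log units; beyond the scatter) for methyl in place of hydrogen on a saturated chain carbon bound to an amine nitrogen in a ring. Among the measured compounds shown here, that step lies beyond the scatter, but it is a much smaller swap, and no measured compound carries a carbonyl on that nitrogen. Its direction therefore cannot simply be carried over. Compound 1 at 1500 nM does show that the same core can give a lower number than compound 3 when the group on nitrogen differs. A modest step towards a lower number in this assay is thus expected, held with little confidence. As an estimate, the expected change is a 2.3-fold lower number from compound 3 to compound 4 (0.37 log units; beyond the scatter) and it could still turn out the other way. The expected value of compound 4 is 3500 nM (estimated range 800 nM to 14000 nM).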

Compound 4, half-maximal inhibitory concentration: 10800 nM
The estimate for compound 4 lay 3.1-fold (0.49 log units) below the measured number; the range from low to high includes it.
By their numbers in this assay, from the lowest: compound 1; then compounds 3, 4 and 2 (each within the scatter of the next).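

On an amine nitrogen in a ring, isopropylcarbonyl in place of ethyl gives a 1.3-fold higher number from compound 3 to compound 4 (0.12 log units; within the scatter) in this assay, so the two groups cannot be told apart here, even though the entering group brings a carbonyl and more heavy atoms. Among these compounds, this is the first measured case with a carbonyl on that nitrogen, and it places the group alongside ethyl on the shared core rather than alongside methyl. Isopropylcarbonyl in place of methyl gives a 7.2-fold higher number from compound 1 to compound 4 (0.86 log units; beyond the scatter), so among these three compounds with the same core, compound 1 alone stands apart, and no measurement shown here explains this result.

The compounds shown leave open whether the lower number of compound 1 belongs to methyl alone or would also appear with a plain hydrogen on that nitrogen, and whether a carbonyl carrying another group, such as acetyl or benzoyl, would read like isopropylcarbonyl. They also leave open how a longer chain ending in an amine or a carboxylic acid at that nitrogen would read in this assay on this core.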